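A few compounds are considered here, and "the series" means these few. Any claim that something is new, unique, unknown or untested is made for them only; others in the source may bear on it.

compound 1 `CCO[C@@H]1OC(=O)[C@](C)(C(C)=O)[C@@H]1C`: > 50000 nM (a limit)
compound 2 `CC(=O)O[C@@H]1OC(=O)[C@@](C)(C(C)=O)[C@@H]1C`: > 10000 nM (a limit)
compound 3 `CC(=O)[C@]1(C)C(=O)O[C@@H](OC(=O)C(C)(C)C)[C@H]1C`: 7000 nM

All three values come from a functional assay on MCF7 cells (Homo sapiens) for cytotoxicity, read by MTT assay; on this read-out lower numbers stand for stronger inhibition and higher numbers for weaker inhibition. Going by the values given here, compound 3 holds the only actual number here, 7000 nM. Compound 1 reports only a limit, and so does compound 2.

The next structure is compound 4 `CCO[C@@H]1OC(=O)[C@@](C)(C(C)=O)[C@@H]1C`. It differs from compound 3 by ethyl in place of (tert-butyl)carbonyl on an oxygen on a saturated carbon.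

Among the compounds with values here, only one measured step bears directly on this change: an at least 1.4-fold lower number from compound 2 to compound 3 (0.15 log units; that floor lies within the scatter). That step puts tert-butyl in place of methyl on a carbonyl carbon, and its floor lies within the scatter, so it offers only a weak hint. The closer guide is compound 1, which also carries an ethyl on such an oxygen and reports only the limit > 50000 nM.

A move beyond the scatter towards a higher number, meaning weaker inhibition, is therefore expected, and the assay may well report only a limit. The expected size is a 5.7-fold higher number from compound 3 to compound 4 (0.76 log units; beyond the scatter). For compound 4 the estimate is 40000 nM, with an expected range from 12000 nM to 100000 nM.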

Compound 4, half-maximal inhibitory concentration: > 50000 nM
Compound 4 ended at the assay's limit (the forecaster's own chance of this, stated with the estimate: 70%); middle value at least 1.2-fold (0.09 log units) from the limit.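

In this assay, ethyl in place of (tert-butyl)carbonyl on this oxygen gives an at least 7.1-fold higher number from compound 3 to compound 4 (0.85 log units; beyond the scatter). This is a clear loss of inhibition, whereas the floor of the earlier step at the carbonyl carbon lay within the scatter. That size is only a floor: compound 4 ended at a limit of the assay, so the true step may be larger, and the steps to compound 4 from compound 2 and from compound 1 cannot be read, as each joins two limits.

On these data alone, compounds 1 and 4 sit at the same limit, so what the drawn configuration at the saturated ring carbon does to the read-out stays unknown: the fact that compounds 1 and 4 differ only in the configuration as drawn Also open is whether the measurable value of compound 3 depends on the (tert-butyl)carbonyl in particular, a question that a benzoyl group or a longer chain on this oxygen could help to answer.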